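The source may hold more compounds than are shown below. What is called first, only, known or untested is meant among the compounds shown, and "the series" means these compounds.

Compound 1 `C[C@H](NC(=O)c1c(Cc2ccc(C(C)(C)C)cc2)sc2c1CCOC2)c1ccc(C(=O)O)cc1` is the reference point. For the measured compounds named here, in a functional assay on CHO/Galpha16 cells for antagonist activity at prostaglandin E2 receptor EP4 subtype (Homo sapiens), read by calcium flux, with a stated time of 15 min (on this read-out lower numbers stand for stronger inhibition and higher numbers for weaker inhibition), compound 1 gives 9.5 nM, the only number among the three values shown. Compound 2 `COC(=O)c1ccc([C@H](C)NC(=O)c2c(Cc3ccc(F)cc3)sc3c2CCOC3)cc1` reaches only the limit > 1000 nM in this assay. Compound 3 `C[C@H](NC(=O)c1c(NC(=O)c2ccc(F)cc2)sc2c1CCOC2)c1ccc(C(=O)O)cc1` likewise reaches only the limit > 1000 nM. The single one-place step shown, an at least 100-fold higher number from compound 1 to compound 3 (2.02 log units; beyond the scatter), rests on (the limit of > 1000 nM in this assay, at which 2 of the 3 values shown sit). Compound 4 `C[C@H](NC(=O)c1c(Cc2ccc(OC(F)(F)F)c(Cl)c2)sc2c1CCOC2)c1ccc(C(=O)O)cc1` differs from compound 1 by 3-chloro-4-(trifluoromethoxy)phenyl in place of 4-(tert-butyl)phenyl on a saturated chain carbon bound to an aromatic carbon. Going by the values given here, no measured step exchanges one aryl group on the benzyl position for another, and the large step of an at least 100-fold higher number from compound 1 to compound 3 (2.02 log units; beyond the scatter) replaces the whole benzyl group rather than its substituents, so it does not bear directly on this change. Compound 4 is therefore expected to show only a small step, a 1.6-fold higher number from compound 1 to compound 4 (0.20 log units; within the scatter). The estimate for compound 4 is 15 nM, between 4 nM and 60 nM.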

Compound 4, half-maximal inhibitory concentration: 6.6 nM
Compound 4: middle estimate off by 2.3-fold (0.36 log units), on the high side, within the range that was stated.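

The step, a 1.4-fold lower number from compound 1 to compound 4 (0.16 log units; within the scatter), shows that 3-chloro-4-(trifluoromethoxy)phenyl can take the place of 4-(tert-butyl)phenyl on this saturated chain carbon bound to an aromatic carbon with no change beyond the scatter in this assay. The earlier one-place step replaced the whole benzyl group, whereas this one exchanges only the aryl group and leaves the rest of compound 1 in place. Nothing shown bears on why the two groups read alike.

On these data alone, it remains open whether the chlorine or the trifluoromethoxy group alone would give the same reading. As far as these compounds go, how an amine or a nitrile on that phenyl ring would read also remains open.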